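The source may report more compounds than this note shows. Statements on the series, on what has been measured and on what is new or still open speak of the compounds shown alone.

Compound 1, `O=C1c2sc(C#Cc3ccccc3)nc2CN1C1CC1`: 23 nM
Compound 2, `CN1CCc2nc(C#Cc3cccc(F)c3)sc2C1`: > 10000 nM (a limit of the assay, not a number)
Compound 3, `CC(=O)N1CCc2nc(C#Cc3ccccc3)sc2C1`: 90 nM

All three were tested in an assay on HEK293 cells for negative allosteric modulation of metabotropic glutamate receptor 5 (Homo sapiens), read by FLIPR, with a stated time of 1 h; on this read-out lower numbers stand for stronger inhibition and higher numbers for weaker inhibition. Compound 2 stands apart: for it the assay reports only a limit, namely (the limit of > 10000 nM in this assay, at which 1 of the 3 values shown sits). Of the two numbers that were actually read, compound 3 carries the higher one, so it is the weaker of that pair; compound 1 sits at a number that is lower by a margin beyond the usual scatter, so that difference is real.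

The next compound keeps the core of compound 3 and changes only the group on the amide carbonyl. Compound 4 is `CC1CC(C(=O)N2CCc3nc(C#Cc4ccccc4)sc3C2)C1`, and it differs from compound 3 in one place: 3-methylcyclobutyl in place of methyl on a carbonyl carbon. The acetyl thus becomes a (3-methylcyclobutyl)carbonyl, a bulkier cap on the same ring nitrogen.

Among the compounds with values here, no measured pair here shows what such an enlargement does, so the expectation rests on the spread seen so far. The step from compound 3 to compound 4 in this assay is expected to be small, towards a lower number, and may well fall within the scatter. Compound 4 is expected to give about 45 nM, with a likely range from 12 nM to 180 nM. That expectation amounts to a step of a 2.0-fold lower number from compound 3 to compound 4 (0.30 log units; within the scatter).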

Compound 4, half-maximal inhibitory concentration: > 10000 nM
Compound 4: no number, only a limit; the forecaster's own chance of this, stated with the estimate: 5%; middle value at least 220-fold (2.34 log units) away from the limit.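

In this assay compound 4 reads > 10000 nM, which is a limit of the assay and not a number. Even read against that limit, the change is an at least 110-fold higher number from compound 3 to compound 4 (2.04 log units; beyond the scatter), so this place on the carbonyl carbon does not accept every replacement for methyl, and exchanging methyl for 3-methylcyclobutyl here is enough on its own to carry the compound out of the measurable range, something no earlier pair could show, as none of them differed in one place only. The result also adds a second compound to those with no readable number, which narrows what can be compared in this set: the limit of > 10000 nM in this assay, at which 2 of the 4 values shown sit.

From the compounds shown here alone, what remains open is which feature of the 3-methylcyclobutyl group matters, the four-membered ring or the extra carbons, and how far beyond the limit compound 4 really lies. Intermediate caps on the same ring nitrogen, such as propionyl with its ethyl group or isobutyryl with its isopropyl group, would show whether the loss sets in gradually or abruptly between methyl and 3-methylcyclobutyl.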